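Amide at the Formyl Position: Compound 4 Expected

The source may report more compounds than this note shows. Statements on the series, on what has been measured and on what is new or still open speak of the compounds shown alone.

This account follows the step from compound 3 to compound 4 in an assay on CHO cells for inhibition of metabotropic glutamate receptor 1 (Rattus norvegicus); a lower number here means a stronger inhibitor, a higher number a weaker inhibitor. Compound 3 `CCCOC(=O)c1[nH]c(C=O)c(C(=O)OC(C)(C)C)c1C` gives 2000 nM, the second highest of the three numbers: compound 1 `CCCOC(=O)c1[nH]c(CO)c(C(=O)OC(C)(C)C)c1C` gives 7900 nM, and compound 2 `CCCOC(=O)c1[nH]cc(C(=O)OC(C)(C)C)c1C` gives 75 nM. Compound 4 `CCCOC(=O)c1[nH]c(C(=O)NCC2CC2)c(C(=O)OC(C)(C)C)c1C` differs from compound 3 by (cyclopropylmethyl)amino in place of hydrogen on a carbonyl carbon. The bearing steps are a 27-fold higher number from compound 2 to compound 3 (1.43 log units; beyond the scatter) and a 4.0-fold lower number from compound 1 to compound 3 (0.60 log units; beyond the scatter); both show that anything other than hydrogen at that aromatic carbon raises the number, and nothing measured tells how a carbamoyl group behaves there. A step of a 1.5-fold higher number from compound 3 to compound 4 (0.18 log units; within the scatter) is therefore expected, with a wide range. Compound 4 is estimated at 3000 nM, between 600 nM and 15000 nM.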

Compound 4, half-maximal inhibitory concentration: 2500 nM
Beside the measured number, compound 4's estimate is 1.2-fold (0.08 log units) above it; measured number inside the range.
By their numbers in this assay, from the lowest: compound 2; then compounds 3 and 4 (each within the scatter of the next); then compound 1.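

In this assay the change from formyl to (cyclopropylmethyl)carbamoyl gives a 1.3-fold higher number from compound 3 to compound 4 (0.10 log units; within the scatter) and so stays within the scatter. The carbamoyl group thus stands with formyl rather than with hydrogen at this aromatic carbon: the change from hydrogen gives a 33-fold higher number from compound 2 to compound 4 (1.52 log units; beyond the scatter) as a large step, and the change from hydroxymethyl gives a 3.2-fold lower number from compound 1 to compound 4 (0.50 log units; beyond the scatter) as a modest one. No supporting data bear on these steps. The compounds shown leave open how an unsubstituted carboxamide, a carboxylic acid or a longer straight chain on the amide nitrogen would read at this carbon.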